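Chloro for hydrogen on the aryl ring of compound 3

The compounds below may be only part of what the source reports. "The series", "measured", "known", "first", "only" and "open" are said of these compounds alone.

Measured so far:
compound 1 `Cc1ccc(S(=O)(=O)n2cc(COC3=C/C(=N\c4ccc(Br)cc4)c4ccccc4C3=O)nn2)cc1` gives 9250 nM;
compound 2 `Cc1ccc(S(=O)(=O)n2cc(COC3=C/C(=N\c4ccc(F)cc4)c4ccccc4C3=O)nn2)cc1` gives 5750 nM;
compound 3 `Cc1ccc(S(=O)(=O)n2cc(COC3=C/C(=N\c4ccccc4)c4ccccc4C3=O)nn2)cc1` gives 5370 nM.

All three numbers come from a functional assay on HCT-116 cells (Homo sapiens) for cytotoxicity, read by MTT assay, with a stated time of 72 h; a lower number here means a stronger inhibitor, a higher number a weaker inhibitor. Compound 3 has the lowest number of the three, but its steps to the others stay within the scatter: a 1.1-fold lower number from compound 2 to compound 3 (0.03 log units; within the scatter) and a 1.7-fold lower number from compound 1 to compound 3 (0.24 log units; within the scatter). Between compound 1 and compound 2 the same holds, a 1.6-fold lower number from compound 1 to compound 2 (0.21 log units; within the scatter). Across bromo, fluoro and hydrogen on that aromatic carbon, therefore, nothing moves beyond the scatter in this assay.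

Compound 4 `Cc1ccc(S(=O)(=O)n2cc(COC3=C/C(=N\c4ccc(Cl)cc4)c4ccccc4C3=O)nn2)cc1` is the next member: chloro in place of hydrogen on an aromatic carbon. Among the measured compounds shown here, the steps that bear on it are those in which bromo or fluoro replaced hydrogen on the same aromatic carbon, and both were small, with the bromo compound showing the highest number of the set. Chloro is expected to behave much like those two, so in this assay compound 4 is expected to show no step beyond the scatter, perhaps a slightly higher number, a 1.2-fold higher number from compound 3 to compound 4 (0.08 log units; within the scatter). The estimate for compound 4 is therefore 6500 nM, with a range from 3500 nM to 12000 nM.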

Compound 4, half-maximal inhibitory concentration: 9440 nM
Compound 4: the middle estimate sits 1.5-fold (0.16 log units) below what was measured; the range from low to high includes it.
By their numbers in this assay, from the lowest: compounds 3, 2, 1 and 4 (each within the scatter of the next).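

In this assay, chloro on this aromatic carbon, para to a large group, gives a step from hydrogen that stays within the scatter (a 1.8-fold higher number from compound 3 to compound 4 (0.24 log units; within the scatter)), and the same holds for its steps from the other two halogens (a 1.6-fold higher number from compound 2 to compound 4 (0.22 log units; within the scatter); a 1.0-fold higher number from compound 1 to compound 4 (0.01 log units; within the scatter)). With chloro added, the set covers fluoro, chloro and bromo, and all three halogens remain within the scatter of the unsubstituted phenyl compound and of one another, so this change from phenyl to 4-chlorophenyl gives no ranking among compounds 1, 2, 3 and 4. No measurement is available here to account for how close these numbers lie.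

The compounds shown leave open whether a group of another kind on this carbon, such as an amine, a carboxylic acid or a methoxy group, would give a step beyond the scatter. They also leave open whether a change in the shared core, away from this aryl ring, would produce a larger step than any seen here.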